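Replacing fluoro with trifluoromethyl on a compound at a limit

The source may report more compounds than this note shows. Statements on the series, on what has been measured and on what is new or still open speak of the compounds shown alone.

Compound 1 `O=C(NCc1ccc(NC(=O)c2cc(F)ccc2N2CCCC2)cc1)OCc1cccnc1` was examined in a toxicity assay on WI-38 cells (Homo sapiens) for inhibition, read by MTT assay, with a stated time of 72 h; on this read-out lower numbers stand for stronger inhibition and higher numbers for weaker inhibition. In this assay compound 1 gives > 100000 nM, which is a limit and not a number. Compound 2 `O=C(NCc1ccc(NC(=O)c2ccc(F)cc2N2CCCC2)cc1)OCc1cccnc1`, which holds the same atoms in a different arrangement, gives > 100000 nM, again a limit and not a number. Among the measured compounds shown here, the whole measured picture is therefore (the limit of > 100000 nM in this assay, at which 2 of the 2 values shown sit), so compound 1 has no exact value, and no measured step shows how far a change on the shared core can move the read-out.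

Compound 3 `O=C(NCc1ccc(NC(=O)c2cc(C(F)(F)F)ccc2N2CCCC2)cc1)OCc1cccnc1` has trifluoromethyl in place of fluoro on an aromatic carbon, meta to a large group and para to a pyrrolidin-1-yl group (trifluoromethyl in place of fluoro on an aromatic carbon). Since compound 1 sits at > 100000 nM there is no measured sign of inhibition to build on, so no change beyond the usual scatter is expected in this assay, and any shift that does appear is expected to be towards stronger inhibition. The expected step is a number no higher from compound 1 to compound 3 (the limit leaves the size open). For compound 3 the estimated value is 100000 nM, with an expected range from 40000 nM to 250000 nM.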

Compound 3, half-maximal inhibitory concentration: > 100000 nM
Compound 3 ended at the assay's limit (the forecaster's own chance of this, stated with the estimate: 70%); the middle value lies on the limit itself.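

In this assay compound 3 gives > 100000 nM, which is a limit and not a number. Among the compounds shown here, compound 1 also stands at a limit, so no step between compound 1 and compound 3 can be read. The compounds shown leave open at what concentration any of them inhibits these cells, and how far a change on the shared core can move the read-out, with the measured picture still this: the limit of > 100000 nM in this assay, at which 3 of the 3 values shown sit.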